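A few compounds are considered here, and "the series" means these few. Any claim that something is new, unique, unknown or untested is made for them only; others in the source may bear on it.

Compound 1, `O=C(/C(=C\c1ccc([N+](=O)[O-])c(O)c1)SCc1ccc(Br)cc1)c1ccc(Br)cc1`, is the compound from which this account starts. In a functional assay on DU-145 cells (Homo sapiens) for inhibition, read by trypan blue exclusion, with a stated time of 96 h (on this read-out higher numbers stand for weaker inhibition of growth and lower numbers for stronger inhibition of growth), compound 1 gives 10000 nM. Two companions have been measured alongside it. Compound 3, `O=C(/C(=C/c1ccc(Br)cc1)S(=O)(=O)Cc1ccc(I)cc1)c1ccc(I)cc1`, gives 20000 nM in this assay, a number close enough to that of compound 1 that the two cannot be told apart within the usual scatter of repeated measurements. Compound 2, `Cc1ccc(CS/C(=C/c2ccc(C)s2)C(=O)c2ccc(Cl)cc2)cc1`, gives 50000 nM in this assay, a number that lies beyond the scatter above compound 1, so compound 1 shows the stronger inhibition of growth of that pair. Among the three measured compounds, compound 1 thus carries the lowest number, though it is separated clearly only from compound 2.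

Compound 4, `O=C(/C(=C\c1ccc([N+](=O)[O-])c(O)c1)SCc1ccc(Br)cc1)c1c(F)c(F)c(F)c(F)c1F`, has not yet been measured. It differs from compound 1 in one place: 2,3,4,5,6-pentafluorophenyl in place of 4-bromophenyl on a carbonyl carbon. Going by the values given here, no pair of measured compounds shares this change, so nothing measured here tells how large a step it brings or in which direction. The three measured values all sit in the same broad region, which gives no ground for expecting a large move either way. On that footing compound 4 is expected to give 15000 nM in this assay, with a plausible range from 4000 nM to 60000 nM. This estimate corresponds to an expected step of a 1.5-fold higher number from compound 1 to compound 4 (0.18 log units; within the scatter), a change within the scatter of the method.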

Compound 4, concentration for 50% growth inhibition: 10000 nM
The estimate for compound 4 lay 1.5-fold (0.18 log units) above the measured number, and the stated range covers the measured number.
By their numbers in this assay, from the lowest: compounds 1, 4 and 3 (each within the scatter of the next); then compound 2.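

In this assay, going by these compounds alone, replacing 4-bromophenyl with 2,3,4,5,6-pentafluorophenyl on a carbonyl carbon brings no change at the digits printed from compound 1 to compound 4 (within the scatter) and gives the first reading in this set between two compounds that differ in one place. With the rest of compound 1 held fixed, a ring carrying five fluorine atoms and a ring carrying one bromine cannot be told apart by this growth read-out, so this position accepts both groups without a visible shift in the number. The data at hand offer no measurement that explains this outcome.

On these data alone, it remains open whether this position would respond to a group of a different kind, such as an amine, a carboxylic acid or a longer alkyl chain in place of the aromatic ring, and whether any such group would move the number clearly in either direction. As far as these compounds go, it is also open whether the same exchange would read the same way on the other cores, those of compound 2 and compound 3, whose remaining groups differ from those of compound 1.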